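Ester change from compound 2 to compound 4

The source may hold more compounds than are shown below. What is called first, only, known or untested is meant among the compounds shown, and "the series" means these compounds.

In a toxicity assay on HUVEC cells (Homo sapiens) for inhibition (on this read-out lower numbers stand for stronger inhibition of growth and higher numbers for weaker inhibition of growth), compound 1 `O=C(Oc1ccccc1)c1ccsc1NC(=O)[C@@H]1CCCN1` gives > 250 ug/mL as a limit of the assay and not a number. Compound 2 `O=C(OC1CCCCC1)c1ccsc1NC(=O)[C@@H]1CCCN1` reads 137 ug/mL and compound 3 `C=CCOC(=O)c1ccsc1NC(=O)[C@@H]1CCCN1` reads 149 ug/mL on the same scale, and these two numbers cannot be told apart. Compound 4 `O=C(OCC(F)(F)F)c1ccsc1NC(=O)[C@@H]1CCCN1` carries 2,2,2-trifluoroethyl in place of cyclohexyl on an oxygen next to a carbonyl group and so has no ring in that group.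

For the measured compounds named here, the closest precedent is allyl in place of cyclohexyl, where a 1.1-fold higher number from compound 2 to compound 3 (0.04 log units; within the scatter) stays within the scatter. The steps of an at least 1.8-fold lower number from compound 1 to compound 2 (0.26 log units; that floor lies within the scatter) and an at least 1.6-fold lower number from compound 1 to compound 3 (0.22 log units; that floor lies within the scatter) have floors within the scatter and rest on the limit of > 250 ug/mL in this assay, at which 1 of the 3 values shown sits, as their shared end, so they add little. No step beyond the scatter is therefore expected in this assay for this change. The expected size is a 1.2-fold higher number from compound 2 to compound 4 (0.07 log units; within the scatter) and no more than that. Compound 4 is estimated at 160 ug/mL with 85 ug/mL to 250 ug/mL as the expected range.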

Compound 4, concentration for 50% growth inhibition: > 250 ug/mL
Compound 4 was reported as a limit; the forecaster's own chance of this, stated with the estimate: 20%; at least 1.5-fold (0.19 log units) between middle value and limit.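

In this assay, a group without a ring, 2,2,2-trifluoroethyl, on an oxygen next to a carbonyl group now also ends at a limit of the assay, so that limit is not confined to phenyl. The change gives an at least 1.8-fold higher number from compound 2 to compound 4 (0.26 log units; that floor lies within the scatter) and an at least 1.6-fold higher number from compound 3 to compound 4 (0.22 log units; that floor lies within the scatter); both floors point the same way, but each lies within the scatter, so no real separation is shown yet. As far as these compounds go, the step between compound 1 and compound 4 cannot be read, and the true size of the other two steps stays open: the limit of > 250 ug/mL in this assay, at which 2 of the 4 values shown sit.

Ethyl on the same oxygen would show whether the fluorine atoms matter on this read-out or whether the small chain alone is enough. From the compounds shown here alone, how a longer chain, or an amine carried on that chain, would read also remains open.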